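Saturating the linker of compound 3

The source may hold more compounds than are shown below. What is called first, only, known or untested is meant among the compounds shown, and "the series" means these compounds.

Working notes on a small series sharing one core. Compound 1 `CC(C)[C@@H](NC(=O)/C=C/c1ccncc1-c1ccc2ccccc2c1)C(=O)O` is recorded as "not determined" (no result reported) in an assay on a protein complex for inhibition of CDK8/Cyclin C (Homo sapiens), with a stated time of 1 h (on this read-out lower numbers stand for stronger inhibition and higher numbers for weaker inhibition), so no number is available for it. Compound 2 `COC1CN(C(=O)/C=C/c2ccncc2-c2ccc3ccccc3c2)C1` gives 42.8 nM in this assay, and compound 3 `COC(=O)/C=C/c1ccncc1-c1ccc2ccccc2c1` gives 40.6 nM; the step of a 1.1-fold lower number from compound 2 to compound 3 (0.02 log units; within the scatter) changes nothing beyond the scatter, so compound 3 holds the lower of the two numbers without being separable from compound 2. Compound 4 `COC(=O)CCc1ccncc1-c1ccc2ccccc2c1` differs from compound 3 by 2-(methoxycarbonyl)ethyl in place of 2-(methoxycarbonyl)ethenyl on an aromatic carbon. For the measured compounds named here, no measured step touches this part of the molecule: the one step known alters the group on the carbonyl carbon only. A weaker number is expected, with wide uncertainty, so the step of a 9.9-fold higher number from compound 3 to compound 4 (0.99 log units; beyond the scatter) is an estimate. For compound 4 the expected value is 400 nM, between 60 nM and 3000 nM.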

Compound 4, half-maximal inhibitory concentration: 259 nM
Compound 4: the middle estimate sits 1.5-fold (0.19 log units) above what was measured; measured number inside the range.
By their numbers in this assay, from the lowest: compounds 3 and 2 (each within the scatter of the next); then compound 4.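

In this assay the linker change gives a 6.4-fold higher number from compound 3 to compound 4 (0.80 log units; beyond the scatter) and so, unlike the change on the carbonyl carbon (a 1.1-fold lower number from compound 2 to compound 3 (0.02 log units; within the scatter)), it moves the number beyond the scatter. At this position, on an aromatic carbon opposite the ring nitrogen, the read-out therefore responds to the loss of one double bond outside aromatic rings, with the heavy-atom count unchanged. No measurement at hand gives a reason for this step. Still open, on these data alone, is whether a carboxylic acid in place of the methoxy group, or a longer chain at this position, would behave in the same way on the saturated linker.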